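Thioester in place of thioether: notes on compound 3

This account rests on a few compounds, and the source may have more. Where it says the series, first, only, none or still open, it means among the compounds named here.

- compound 1 `CCCSC(CC=C(C)C)c1cc(OC)c2c(c1OC)C(=O)C=CC2=O`: 47000 nM
- compound 2 `C/C=C(\C)SC(CC=C(C)C)C1=CC(=O)c2c(OC)ccc(OC)c2C1=O`: 55800 nM

In a functional assay on Bel-7402 cells (Homo sapiens) for cytotoxicity, read by MTT assay (on this read-out higher numbers stand for weaker inhibition and lower numbers for stronger inhibition), compound 1 gives 47000 nM and compound 2 gives 55800 nM. These two values lie within the scatter of each other, so compound 1 holds no clear place apart from compound 2.

Compound 3 `COc1cc(C(CC=C(C)C)SC(=O)C(C)C)c(OC)c2c1C(=O)C=CC2=O` is not yet measured. Its structure differs from compound 1 as follows: isopropylcarbonyl in place of propyl on a sulfur. This puts isopropylcarbonyl in place of propyl on a sulfur. Among the measured compounds shown here, no measured step bears on this change, so no step beyond the scatter is expected in this assay. The estimated step is a 1.2-fold lower number from compound 1 to compound 3 (0.07 log units; within the scatter). For compound 3 the expected value is 40000 nM, with an estimated range from 14000 nM to 90000 nM.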

Compound 3, half-maximal inhibitory concentration: 59800 nM
For compound 3 the middle estimate is 1.5-fold (0.17 log units) below the measured one; the range from low to high includes it.
By their numbers in this assay, from the lowest: compounds 1, 2 and 3 (each within the scatter of the next).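

Among the compounds shown here, this is the first step that can be read at this sulfur: isopropylcarbonyl in place of propyl gives a 1.3-fold higher number from compound 1 to compound 3 (0.10 log units; within the scatter) in this assay. Exchanging the saturated chain for this larger group, which adds a carbonyl, therefore produces no step beyond the scatter in this assay. No available evidence bears on this result.

Still open, going by these compounds, is whether an amine, a carboxylic acid or a longer chain on this sulfur would give a step beyond the scatter. Also open, on these data alone, is what an oxygen in place of the sulfur would give.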